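Methoxy for Methyl on the Aryl Ring

The source may hold more compounds than are shown below. What is called first, only, known or untested is meant among the compounds shown, and "the series" means these compounds.

Among the three measured compounds, compound 3 `Cc1ccc(C2C(C#N)=C(N)OC(c3c[nH]c4ccccc34)=C2C#N)cc1` stands second highest in a functional assay, tested at 50 ug/mL (a higher number here means a stronger effect of the compound at the concentration tested, a lower number a weaker effect), where compound 3 gives 5.2%. Its nearest neighbour is compound 1 `N#CC1=C(N)OC(c2c[nH]c3ccccc23)=C(C#N)C1c1cccc2ccccc12`, which in this assay gives 4.7%. The furthest is compound 2 `N#CC1=C(N)OC(c2c[nH]c3ccccc23)=C(C#N)C1c1ccccc1Cl`, which in this assay gives 8.5%. All three numbers lie within the scatter of one another. Compound 4 `COc1ccc(C2C(C#N)=C(N)OC(c3c[nH]c4ccccc34)=C2C#N)cc1` differs from compound 3 in a single place: methoxy in place of methyl on an aromatic carbon. Within the data shown here, no measured pair exchanges this group, so the closest guides are the steps that swap the whole aryl ring on the saturated ring carbon, namely a number 0.5 percentage points higher from compound 1 to compound 3 (within the scatter) and a number 3.3 percentage points lower from compound 2 to compound 3 (within the scatter), with a number 3.8 percentage points higher from compound 1 to compound 2 (within the scatter) alongside. None of these moved this assay beyond the scatter, so for compound 4 the step of a number 0.3 percentage points higher from compound 3 to compound 4 (within the scatter) is expected to stay within the scatter as well, in no clear direction. Compound 4 is therefore estimated at 5.5% in this assay, within a range from 0% to 15%.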

Compound 4, a percentage reported as activity, at one concentration (the size of the read-out at that concentration, not a potency): 12.4%
Compound 4: the middle estimate sits 6.9 percentage points below what was measured; measured number inside the range.
By their numbers in this assay, from the lowest: compounds 1, 3, 2 and 4 (each within the scatter of the next).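

Methoxy in place of methyl on an aromatic carbon, para to a large group, is the first change in this series confined to a single group on the aryl ring, and in this assay this 4-methylphenyl to 4-methoxyphenyl exchange remains within the scatter (a number 7.2 percentage points higher from compound 3 to compound 4 (within the scatter)). The 4-methoxyphenyl group also stays within the scatter of the two other aryl groups (a number 3.9 percentage points higher from compound 2 to compound 4 (within the scatter); a number 7.7 percentage points higher from compound 1 to compound 4 (within the scatter)), so no aryl group shown here separates from another in this assay. No measurement available here accounts for the size of these steps.

The compounds shown leave open whether a hydroxy group, an ethoxy chain or an amine on this aromatic carbon would give a step beyond the scatter in this assay. They also leave open how methoxy would read on the 2-chlorophenyl ring.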